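A Thiourea Aryl Swap on a Cyclohexylamide Scaffold

This account rests on a few compounds, and the source may have more. Where it says the series, first, only, none or still open, it means among the compounds named here.

Compound 2 `O=C(NC1CCCCC1)c1cc(Oc2cccc(NC(=S)Nc3ccc(F)c(F)c3)c2)ccn1` holds the lowest number of the three measured compounds in a functional assay on PC-3 cells (Homo sapiens) for cytotoxicity, read by MTT assay, with a stated time of 48 h (on this read-out higher numbers stand for weaker inhibition and lower numbers for stronger inhibition), giving 8100 nM. Compound 1 `O=C(NCc1ccccc1)c1cc(Oc2cccc(NC(=S)Nc3ccc(Cl)cc3)c2)ccn1` gives 15800 nM, within the scatter of compound 2, so the two cannot be ordered. Within the data shown here, compound 3 `O=C(c1cc(Oc2cccc(NC(=S)Nc3ccc(F)c(F)c3)c2)ccn1)N1CCCC1` gives 45600 nM, and the one measured step, a 5.6-fold higher number from compound 2 to compound 3 (0.75 log units; beyond the scatter), concerns the amide side rather than the thiourea aryl ring. Compound 4 `O=C(NC1CCCCC1)c1cc(Oc2cccc(NC(=S)Nc3cccc(C(F)(F)F)c3)c2)ccn1` differs from compound 2 by 3-(trifluoromethyl)phenyl in place of 3,4-difluorophenyl on an amide-type nitrogen. Among the measured compounds shown here, no measured pair bears on this change; compound 1 carries another aryl but also another amide, so its value only shows the range the series occupies. A step of a 1.1-fold higher number from compound 2 to compound 4 (0.05 log units; within the scatter) is therefore expected, nothing beyond the scatter. Compound 4 is estimated at 9000 nM, ranging from 3000 nM to 27000 nM.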

Compound 4, half-maximal inhibitory concentration: 16800 nM
Estimate against measurement, compound 4: 1.9-fold (0.27 log units) below; measured number inside the range.
By their numbers in this assay, from the lowest: compounds 2, 1 and 4 (each within the scatter of the next, the first and the last beyond it); then compound 3.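

On the cyclohexylamide scaffold, the aryl ring on the thiourea nitrogen proves able to move the number in this assay: 3-(trifluoromethyl)phenyl in place of 3,4-difluorophenyl gives a 2.1-fold higher number from compound 2 to compound 4 (0.32 log units; beyond the scatter) and so a modest loss, only just past the scatter. Among these compounds, this is the first reading of a change at this position, as the earlier step concerned the amide side. Nothing at hand accounts for the size of this step.

The compounds shown leave open how a simple phenyl, a methoxy group or a nitrile on this ring would read. They also leave open whether the same swap holds with the pyrrolidin-1-yl amide of compound 3.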